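Swapping the Amide Substituent of Compound 1

The compounds below may be only part of what the source reports. "The series", "measured", "known", "first", "only" and "open" are said of these compounds alone.

Compound 1 `COCCNC(=O)c1cc2cccc(OC)c2oc1=N`: 43%
Compound 2 `O=C(NC1CCCC1)c1cc2ccccc2oc1=O`: 18%
Compound 3 `COc1cc(Br)cc2cc(C(=O)NCCCO)c(=N)oc12`: 30%

In an assay on HEK293 cells for displacement of a labelled ligand from adenosine receptor A2b (Homo sapiens), read by scintillation counting, with a stated time of 30 min, tested at 10 uM (a lower number here means less inhibition, a higher number more inhibition at the concentration tested (going by the name of the read-out)), compound 1 gives 43%, the highest of the three numbers. Compound 3 follows with 30%, a gap beyond the scatter, and compound 2 sits furthest away with 18%. Compound 4 `COc1cccc2cc(C(=O)NC3CCCC3)c(=N)oc12` has not yet been measured. It differs from compound 1 in one place: cyclopentyl in place of 2-methoxyethyl on an amide-type nitrogen. Within the data shown here, no pair of measured compounds isolates this change; compound 2 carries cyclopentylamino on a different core, so its lower number cannot be attributed to the amide substituent alone. A small step, downward or none beyond the scatter, is expected: a number 8 percentage points lower from compound 1 to compound 4 (within the scatter). Compound 4 is therefore estimated to give 35%, within a range from 15% to 55%.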

Compound 4, a percentage reported as inhibition, at one concentration (the size of the read-out at that concentration, not a potency): 47%
Beside the measured number, compound 4's estimate is 12 percentage points below it; the measured number falls inside the stated range.
By their numbers in this assay, from the lowest: compound 2; then compound 3; then compounds 1 and 4 (each within the scatter of the next).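

In this assay, among these compounds, the change to cyclopentyl in place of 2-methoxyethyl on an amide-type nitrogen gives a number 4 percentage points higher from compound 1 to compound 4 (within the scatter) on an otherwise unchanged compound, which the earlier compounds could not show. At this position, then, a five-membered carbon ring and the open 2-methoxyethyl chain give numbers within the scatter of each other. Nothing at hand explains this result. As far as these compounds go, whether an amine, a carboxylic acid or a longer chain on this nitrogen would keep the number there remains open.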